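The source may hold more compounds than are shown below. What is called first, only, known or untested is meant among the compounds shown, and "the series" means these compounds.

Compound 1 `Cn1cncc1CN1CC(N(CC2CCN(C(=O)CC(C)(C)C)CC2)S(=O)(=O)c2ccccn2)Cc2cc(C#N)ccc21` gives 0.5 10^-6 cm/s in an ADME assay on Caco-2 cells (Homo sapiens) for permeability, in the apical to basolateral direction; on this read-out higher numbers stand for higher permeability and lower numbers for lower permeability. Compound 2 `Cn1cncc1CN1CC(N(CC2CCN(C(=O)c3cccs3)CC2)S(=O)(=O)c2ccccn2)Cc2cc(C#N)ccc21` gives 0.5 10^-6 cm/s in this assay, and compound 3 `Cn1cncc1CN1CC(N(CC2CCN(C(=O)N3CCCCC3)CC2)S(=O)(=O)c2ccccn2)Cc2cc(C#N)ccc21` gives 0.6 10^-6 cm/s. The values of compound 1 and compound 2 are level, and compound 3 sits within the scatter of both: no change at the digits printed from compound 1 to compound 2 (within the scatter), a 1.2-fold higher number from compound 1 to compound 3 (0.08 log units; within the scatter), a 1.2-fold higher number from compound 2 to compound 3 (0.08 log units; within the scatter).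

Compound 4 `CC(C)C(=O)N1CCC(CN(C2Cc3cc(C#N)ccc3N(Cc3cncn3C)C2)S(=O)(=O)c2ccccn2)CC1` differs from compound 1 by isopropyl in place of neopentyl on a carbonyl carbon. The three measured steps also exchange the group on the same carbonyl carbon, and none of them moves the number beyond the scatter, so no step beyond the scatter is expected here either. Compound 4 is therefore expected to give 0.5 10^-6 cm/s in this assay, within 0.3 10^-6 cm/s to 0.9 10^-6 cm/s, which means an estimated no change at the digits printed from compound 1 to compound 4 (within the scatter).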

Compound 4, apparent permeability: 0.5 10^-6 cm/s
Estimate against measurement, compound 4: no gap at the digits printed, and the stated range covers the measured number.
By their numbers in this assay, from the lowest: compounds 1, 2, 4 and 3 (each within the scatter of the next).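

Isopropyl, with 3 heavy atoms against the 5 of neopentyl, extends the series to a shorter group on this carbonyl carbon, and this assay still stays within the scatter: no change at the digits printed from compound 1 to compound 4 (within the scatter) and no change at the digits printed from compound 2 to compound 4 (within the scatter) and a 1.2-fold lower number from compound 3 to compound 4 (0.08 log units; within the scatter) are what the compound shows. So four groups on this carbonyl carbon, with or without a ring, now sit within the scatter of one another. Nothing measured here offers an explanation for this. Still open, from the compounds shown here alone, is whether a group carrying an amine or a carboxylic acid on this carbonyl carbon would stay within the scatter, and whether exchanging the nitrile on the shared core would move the number.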